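The source may hold more compounds than are shown below. What is called first, only, known or untested is meant among the compounds shown, and "the series" means these compounds.

In an ADME assay on microsomes from liver (Homo sapiens) for metabolic stability, with a stated time of 60 min, tested at 1 uM (on this read-out higher numbers stand for a more stable compound and lower numbers for a less stable compound), compound 1 (`Cn1cc(-c2nc3c(-c4ccnc(OC5CC5)c4)cnn3cc2OCCCC(C)(C)O)cn1`) gives 54% and compound 2 (`COc1cn2ncc(-c3ccnc(OC(C)C)c3)c2nc1-c1cnn(C)c1`) gives 32%, the lower of the two numbers, with a gap beyond the usual scatter. Compound 3 (`COc1cn2ncc(-c3ccnc(OC4CC4)c3)c2nc1-c1cnn(C)c1`) differs from compound 2 in one place: cyclopropyl in place of isopropyl on an oxygen on an aromatic ring. Within the data shown here, no measured pair shows this change, so only a modest rise in this assay is expected, and one within the scatter would not surprise. The expected size is a number 8 percentage points higher from compound 2 to compound 3 (within the scatter). For compound 3 the estimated value is 40%, with an expected range of 24% to 58%.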

Compound 3, percent of the compound remaining: 47%
Beside the measured number, compound 3's estimate is 7 percentage points below it; the measured number falls inside the stated range.
By their numbers in this assay, from the lowest: compound 2; then compounds 3 and 1 (each within the scatter of the next).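

In this assay, among these compounds, isopropoxy to cyclopropyloxy on the aromatic ring gives a number 15 percentage points higher from compound 2 to compound 3 (beyond the scatter), the first direct reading of this change at this oxygen. The second step, a number 7 percentage points lower from compound 1 to compound 3 (within the scatter), shows that hydrogen can stand in place of 3-hydroxy-3-methylbutyl on the saturated chain carbon without a difference beyond the scatter. No measurement shown here accounts for either step.

On these data alone, whether another group on this oxygen, such as a cyclobutyl or a longer chain, would read the same stays open. So does the size of the isopropyl to cyclopropyl step when 3-hydroxy-3-methylbutyl is present.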